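This account rests on a few compounds, and the source may have more. Where it says the series, first, only, none or still open, it means among the compounds named here.

Working notes on the series. Compound 1 `O/N=C(/Nc1cccc(Cl)c1)c1ccc2occc2c1` is the reference here; in an assay on isolated protein for inhibition of Indoleamine 2,3-dioxygenase 1 (Homo sapiens), read by spectrophotometry (a higher number here means a weaker inhibitor, a lower number a stronger inhibitor), compound 1 gives 690 nM, the lowest of the two numbers shown. Compound 2 `O/N=C(/Nc1cccc(Oc2ccccc2)c1)c1ccc2occc2c1` sits at a limit of this assay, > 30000 nM (the limit of > 30000 nM in this assay, at which 1 of the 3 values shown sits). Compound 3 `O/N=C(/Nc1cccc(-c2ccccc2)c1)c1ccc2occc2c1` gives 11000 nM in this assay. The measured steps are an at least 43-fold higher number from compound 1 to compound 2 (1.63 log units; beyond the scatter), a 16-fold higher number from compound 1 to compound 3 (1.20 log units; beyond the scatter) and an at least 2.7-fold lower number from compound 2 to compound 3 (0.43 log units; beyond the scatter); both steps from compound 1 put a phenyl-sized group where the chloro was and weakened binding strongly.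

Compound 4 `O/N=C(/Nc1cccc(Cl)c1)c1ccc2oc(-c3ccccc3)cc2c1` carries a different change: phenyl in place of hydrogen on an aromatic carbon. For the measured compounds named here, no measured step touches this place, so the measured steps bear only loosely; the phenyl additions so far weakened binding, so a modest weakening is expected, a 2.2-fold higher number from compound 1 to compound 4 (0.34 log units; beyond the scatter). Compound 4 is estimated at 1500 nM, within 400 nM to 6000 nM.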

Compound 4, half-maximal inhibitory concentration: 900 nM
Estimate against measurement, compound 4: 1.7-fold (0.22 log units) above; measured number inside the range.
By their numbers in this assay, from the lowest: compounds 1 and 4 (each within the scatter of the next); then compound 3. At a limit, above all of these: compound 2.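

In this assay, phenyl in place of hydrogen next to the ring oxygen gives a 1.3-fold higher number from compound 1 to compound 4 (0.12 log units; within the scatter) and so leaves the number of compound 1 within the scatter. A phenyl group therefore does not weaken binding at every place, as a 16-fold higher number from compound 1 to compound 3 (1.20 log units; beyond the scatter) alone might have suggested when phenyl replaced chloro. Nothing measured in the series explains why the two places differ.

Going by these compounds, whether methyl, an amine, a carboxylic acid or a longer chain at this place would behave like phenyl remains open. So does whether substituted phenyl rings would be accepted here.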